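The compounds below may be only part of what the source reports. "The series", "measured", "known", "first", "only" and "open" are said of these compounds alone.

Measured compounds in a functional assay on HFL1 cells for antagonist activity at sphingosine 1-phosphate receptor 2 (Homo sapiens), read by ELISA, with a stated time of 24 h, in the absence of a further agent; a higher number here means a weaker inhibitor, a lower number a stronger inhibitor:

Compound 1 `CCOc1cc(NC(=O)NCc2cc(C)c(-c3cn(C)nc3C(F)(F)F)nn2)cc(C#N)n1` gives 35 nM.
Compound 2 `Cc1cc(CNC(=O)Nc2cc(OCCO)nc(C(F)(F)F)c2)nnc1-c1cn(C)nc1C(F)(F)F` gives 704 nM.
Compound 3 `CCOc1nc(C#N)cc(NC(=O)NCc2cc(C)c(-c3cn(C)nc3C(F)(F)F)nn2)c1C` gives 24 nM.

Compound 1 and compound 3 share a core and differ by methyl in place of hydrogen on an aromatic carbon. This change produced a 1.5-fold lower number from compound 1 to compound 3 (0.16 log units; within the scatter). Compound 2 has the highest number of the three; the difference between its core and the core of compound 1 is not broken down here.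

Compound 4 `Cc1cc(CNC(=O)Nc2cc(C(F)(F)F)nc(OCCO)c2C)nnc1-c1cn(C)nc1C(F)(F)F` is not yet measured. It differs from compound 2 by methyl in place of hydrogen on an aromatic carbon. This is the same kind of change as that from compound 1 to compound 3, not the same: in compound 4 the new methyl stands ortho to a 2-hydroxyethoxy group and para to a trifluoromethyl group, whereas in compound 3 it stands ortho to an ethoxy group and para to a cyano group.

Among the measured compounds shown here, since the one measured instance of this kind of change stayed within the scatter, compound 4 is expected to show a 1.4-fold lower number from compound 2 to compound 4 (0.15 log units; within the scatter), a step of about the same size as the earlier one. Compound 4 is therefore estimated at 500 nM, with a likely range from 200 nM to 1400 nM.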

Compound 4, half-maximal inhibitory concentration: 160 nM
The estimate for compound 4 lay 3.1-fold (0.49 log units) above the measured number; the measured number lies below the stated range.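

In this assay, methyl in place of hydrogen on an aromatic carbon produces a 4.4-fold lower number from compound 2 to compound 4 (0.64 log units; beyond the scatter), a modest step that can be read as real on this core. The size of the step therefore did not carry over unchanged from one core to the other: the same change on two cores in this assay, a 1.5-fold lower number (0.16 log units; within the scatter) from compound 1 to compound 3 and a 4.4-fold lower number (0.64 log units; beyond the scatter) from compound 2 to compound 4, 3.0-fold (0.48 log units) apart, beyond the scatter of two such steps This does not show what sets the size of the step, since the two cores differ in more than one group, ethoxy against 2-hydroxyethoxy and nitrile against trifluoromethyl, and two pairs cannot separate these or give a rule for any further core.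

The compounds shown leave open whether a core combining the ethoxy group with the trifluoromethyl group, or the 2-hydroxyethoxy group with the nitrile, would give a step nearer the first or the second. They also leave open how an ethyl group or a chlorine atom on the same aromatic carbon would compare with the methyl.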